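Cytotoxicity of a pyrazolopyridine-type series: methyl for hydrogen

A few compounds are considered here, and "the series" means these few. Any claim that something is new, unique, unknown or untested is made for them only; others in the source may bear on it.

Measured so far in an ADME assay on BJ cells (Homo sapiens) for cytotoxicity, with a stated time of 72 h; on this read-out higher numbers stand for an effect only at larger amounts of compound and lower numbers for an effect already at smaller amounts:
Compound 1, `CCc1ccc(-c2nc3c(c(C)nn3-c3ccccc3)c(-c3ccccc3O)c2C#N)cc1`, gives > 20000 nM.
Compound 2, `COc1cccc(-c2nc3c(c(C)nn3-c3ccccc3)c(-c3ccccc3O)c2C#N)c1`, gives > 23000 nM.
Compound 3, `Cc1nn(-c2ccccc2)c2nc(-c3ccccc3)c(C#N)c(-c3ccccc3O)c12`, gives > 23000 nM.

Each of these three values is a limit of this assay, not a number. For compound 1 the value is the limit (the limit of > 20000 nM in this assay, at which 1 of the 3 values shown sits). For compound 2 and compound 3 the value is the limit (the limit of > 23000 nM in this assay, at which 2 of the 3 values shown sit). Compound 3 therefore stands only at a limit, as do the two other values shown, and no ordering among the three compounds can be read.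

Compound 4, `Cc1ccc(-c2nc3c(c(C)nn3-c3ccccc3)c(-c3ccccc3O)c2C#N)cc1`, differs from compound 3 by methyl in place of hydrogen on an aromatic carbon.

The measured steps that bear on a small change on an aromatic carbon of the same ring are those from compound 1 to compound 2, a step that the two limits leave unreadable from compound 1 to compound 2, from compound 1 to compound 3, a step that the two limits leave unreadable from compound 1 to compound 3, and from compound 2 to compound 3, a step that the two limits leave unreadable from compound 2 to compound 3. None of them has a readable size, since both ends sit at a limit. Nothing in these data shows any change on this ring moving the read-out into the measurable range, so no step beyond the scatter is expected for this assay. The expected step is a step that the limit leaves unreadable from compound 3 to compound 4. Compound 4 is estimated at 25000 nM, with a range from 12000 nM to 60000 nM, most probably reported again only as a limit.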

Compound 4, half-maximal effective concentration: 22200 nM
Compound 4: the middle estimate sits 1.1-fold (0.05 log units) above what was measured; the measured number falls inside the stated range.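

Compound 4, with methyl at this place on an aromatic carbon para to a large group, is the first compound shown to give a number rather than a limit in this assay. Methyl in place of hydrogen appears as an at least 1.0-fold lower number from compound 3 to compound 4 (0.01 log units; that floor lies within the scatter), and 4-methylphenyl in place of 3-methoxyphenyl appears as an at least 1.0-fold lower number from compound 2 to compound 4 (0.01 log units; that floor lies within the scatter); both are only floors within the scatter, so neither shows that the change moved the read-out. The value of compound 3, the reference for the methyl step, remains a limit and not a number: the limit of > 23000 nM in this assay, at which 2 of the 4 values shown sit.

From the compounds shown here alone, the step between compound 1 and compound 4 cannot be read, so the ethyl and methyl compounds cannot be set in order, and the true size of the methyl step also stays open. Going by these compounds, it also stays open whether an amine or a carboxylic acid on this ring, or a chain longer than the ethyl of compound 1, would give a number clearly apart from these limits.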